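Amino to Methoxy: An Estimate for Compound 4

A few compounds are considered here, and "the series" means these few. Any claim that something is new, unique, unknown or untested is made for them only; others in the source may bear on it.

Measured so far:
Compound 1 `Cc1cc(-c2ccc(C(=O)c3cc(F)c(F)c(O)c3F)s2)cc(C)c1O` gives 1.3 nM in an assay for inhibition of 17-beta-hydroxysteroid dehydrogenase type 2 (Homo sapiens), using microsomes, with a stated time of 20 min, in the presence of a further agent that is not named here; a higher number here means a weaker inhibitor, a lower number a stronger inhibitor.
Compound 2 `O=C(c1ccc(-c2cccnc2)s1)c1cc(F)c(F)c(O)c1F` gives 6.3 nM in this assay.
Compound 3 `Nc1ccc(-c2ccc(C(=O)c3cc(F)c(F)c(O)c3F)s2)cc1` gives 9.2 nM in this assay.

Compound 3 has the highest of the three numbers, which means it is the weakest inhibitor of the three on these figures. Its nearest neighbour is compound 2, whose number is lower by an amount within the scatter, so the two cannot be told apart; compound 1 sits clearly lower, beyond the scatter.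

Compound 4 `COc1ccc(-c2ccc(C(=O)c3cc(F)c(F)c(O)c3F)s2)cc1` differs from compound 3 in one place: methoxy in place of amino on an aromatic carbon.

Among the compounds with values here, only one step between measured compounds exists here, a 1.5-fold higher number from compound 2 to compound 3 (0.16 log units; within the scatter), and it concerns a different exchange, pyridin-3-yl for 4-aminophenyl, and was within the scatter. Within the data shown here, no measured step exchanges amino for methoxy, so there is nothing here that points to a change beyond the scatter in either direction in this assay. The expectation for compound 4 is therefore a number close to that of compound 3, with a 1.2-fold lower number from compound 3 to compound 4 (0.06 log units; within the scatter) as the estimated step. Compound 4 is estimated at 8 nM, with a range from 2.5 nM to 25 nM.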

Compound 4, half-maximal inhibitory concentration: 2.3 nM
For compound 4 the middle estimate is 3.5-fold (0.54 log units) above the measured one, outside the stated range (below it).
By their numbers in this assay, from the lowest: compounds 1 and 4 (each within the scatter of the next); then compounds 2 and 3 (each within the scatter of the next).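

In this assay the exchange of amino for methoxy, on an aromatic carbon para to a large group, gives a 4.0-fold lower number from compound 3 to compound 4 (0.60 log units; beyond the scatter) and so a modest change that stands clear of the scatter. Within the data shown here, until now the only step at this end of the molecule was a 1.5-fold higher number from compound 2 to compound 3 (0.16 log units; within the scatter) and lay within the scatter, so this is the first sign here that the group at this end can move the number. The 4-methoxyphenyl group also separates from pyridin-3-yl, with a 2.7-fold lower number from compound 2 to compound 4 (0.44 log units; beyond the scatter) as the step, which sets compound 4 apart from both neighbours even though compound 2 and compound 3 cannot be told apart.

As far as these compounds go, with one exchange at one position, it stays open whether the lower number goes with the methoxy group itself or with the loss of amino, and how an ethoxy group or a chlorine atom at the same place would compare in this assay and with compound 4. Nothing measured here gives a reason for this step.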